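A smaller amine group on the core of compound 1

This account rests on a few compounds, and the source may have more. Where it says the series, first, only, none or still open, it means among the compounds named here.

Measured so far in an assay (strain Wistar) for inhibition of Amine oxidase [flavin-containing] A (Rattus norvegicus); on this read-out higher numbers stand for weaker inhibition and lower numbers for stronger inhibition:
compound 1 `NC(=O)[C@@H]1CCCN1c1cc(=O)oc2cc(OCc3ccccc3)ccc12` gives 99800 nM
compound 2 `NC(=O)Cc1cc(=O)oc2cc(OCc3cccc(Cl)c3)ccc12` gives 26000 nM
compound 3 `NC(=O)Cc1cc(=O)oc2cc(OCc3ccncc3)ccc12` gives 26500 nM

Compound 1 stands highest of the three numbers and is therefore the weakest inhibitor here, with compound 3 and compound 2 both lying below it beyond the scatter. Compound 4 `CN(C)Cc1cc(=O)oc2cc(OCc3ccccc3)ccc12` arises from compound 1 by a single change: (dimethylamino)methyl in place of 2-carbamoylpyrrolidin-1-yl on an aromatic carbon. Among the compounds with values here, no measured step covers this change. Within the data shown here, the only step measured, a 1.0-fold higher number from compound 2 to compound 3 (0.01 log units; within the scatter), alters the group bound through the oxygen on the other ring and leaves the position in question untouched, so it gives no guidance for the present change. What the values do show is that compound 2 and compound 3, which carry a different small group on that aromatic carbon, sit well below compound 1, so a smaller group there is at least not punished. Compound 4 is therefore expected near 30000 nM, in a range from 6000 nM to 150000 nM. That expectation amounts to a step of a 3.3-fold lower number from compound 1 to compound 4 (0.52 log units; beyond the scatter).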

Compound 4, half-maximal inhibitory concentration: 100000 nM
Compound 4: middle estimate off by 3.3-fold (0.52 log units), on the low side, within the range that was stated.
By their numbers in this assay, from the lowest: compounds 2 and 3 (each within the scatter of the next); then compounds 1 and 4 (each within the scatter of the next).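

In this assay, placing (dimethylamino)methyl instead of 2-carbamoylpyrrolidin-1-yl on this aromatic carbon gives a 1.0-fold higher number from compound 1 to compound 4 (0.00 log units; within the scatter). The group drops from 8 heavy atoms to 4 and loses its ring, its defined stereocentre and its hydrogen-bond donor, yet the two numbers lie within the scatter of each other, so in this pair a smaller group on this carbon brings no gain in inhibition. No supporting measurement is available to explain this result.

Compound 2 and compound 3 differ from compound 1 and compound 4 in more than one place, so they cannot show what the group on this carbon contributes by itself. As far as these compounds go, whether a carboxylic acid or a longer chain ending in an amine on this carbon would give a different number remains open.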